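Solubility at a Single Imidazole Exchange

The source may hold more compounds than are shown below. What is called first, only, known or untested is meant among the compounds shown, and "the series" means these compounds.

Measured so far:
compound 1, `Cc1cc(Cl)c(-c2ncc[nH]2)cc1NC(=O)c1ccc(OCc2ccccn2)cc1`: < 1000 nM
compound 2, `Cc1ccc(-c2nccn2C)cc1NC(=O)c1ccc(OCc2ccccn2)cc1`: 192000 nM

Of the compounds shown here, two have been measured in a physicochemical assay for solubility, at pH 7.4; on this read-out higher numbers stand for higher solubility and lower numbers for lower solubility. Compound 1 gives only a limit, < 1000 nM, and not a number, which is the limit noted in the limit of < 1000 nM in this assay, at which 1 of the 2 values shown sits. Among the compounds with values here, compound 2 gives 192000 nM, the only real number in this assay so far, so its position among the measured values can only be described as the one value that is not a limit.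

Compound 3, `Cc1ccc(-c2c[nH]cn2)cc1NC(=O)c1ccc(OCc2ccccn2)cc1`, has not yet been measured. It differs from compound 2 in one place: 1H-imidazol-4-yl in place of 1-methyl-1H-imidazol-2-yl on an aromatic carbon. Within the data shown here, no pair of measured compounds shows this exchange, so no measured step is available to lean on.

Compound 3 is therefore expected to fall somewhat lower than compound 2 in this assay, with a step of a 4.8-fold lower number from compound 2 to compound 3 (0.68 log units; beyond the scatter), beyond the scatter but not to the limit. The estimate for compound 3 is 40000 nM, within 5000 nM to 150000 nM.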

Compound 3, solubility: 90000 nM
Beside the measured number, compound 3's estimate is 2.3-fold (0.35 log units) below it; low and high end bracket the measured number.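

The exchange of 1-methyl-1H-imidazol-2-yl for 1H-imidazol-4-yl, on an aromatic carbon para to a methyl group, now has a measured size in this assay, giving a 2.1-fold lower number from compound 2 to compound 3 (0.33 log units; beyond the scatter). Within the data shown here, this is a modest step, and it shows that this position can carry an imidazole with 1 hydrogen-bond donor in place of one with none while the number stays of a similar order, a point the earlier compounds could not show because no measured pair held this exchange. Compound 1 remains the only compound shown whose result is a limit and not a number: the limit of < 1000 nM in this assay, at which 1 of the 3 values shown sits.

The compounds shown do not separate the loss of the methyl group from the change in how the imidazole is attached, so neither part of the exchange can be given its own share of the step, and nothing here gives a measured reason for it. Also open, from the compounds shown here alone, is how this assay would respond to an amine or a carboxylic acid on the same aromatic carbon in place of either imidazole.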